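The source may hold more compounds than are shown below. What is called first, only, known or untested is meant among the compounds shown, and "the series" means these compounds.

Measured so far:
compound 1 `Cc1cccc2[nH]c(-c3n[nH]c4ncc(-c5cncc6ccccc56)cc34)nc12`: "not determined" (no result reported) in an assay on isolated protein for inhibition of proto-oncogene tyrosine-protein kinase receptor Ret (Homo sapiens); a lower number here means a stronger inhibitor, a higher number a weaker inhibitor
compound 2 `COCc1cccc2[nH]c(-c3n[nH]c4ncc(-c5cccnc5)cc34)nc12`: 1100 nM

In this assay, within the data shown here, compound 2 stands as the only number of the series; compound 1 carries no result and offers no comparison. Compound 3 `COCc1cccc2[nH]c(-c3n[nH]c4ncc(-c5cncnc5)cc34)nc12` is not yet measured. It differs from compound 2 in one place: pyrimidin-5-yl in place of pyridin-3-yl on an aromatic carbon. Among the measured compounds shown here, no step between two measured compounds is available, so the size of this change has no precedent within the set. The expected step is small, at most the usual scatter and if anything toward a slightly weaker inhibitor, estimated as a 1.4-fold higher number from compound 2 to compound 3 (0.13 log units; within the scatter). Compound 3 is accordingly expected near 1500 nM, within a range of 500 nM to 4500 nM.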

Compound 3, half-maximal inhibitory concentration: > 100000 nM
Compound 3 was reported as a limit; the forecaster's own chance of this, stated with the estimate: 5%; middle value at least 66-fold (1.82 log units) from the limit.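

Pyrimidin-5-yl in place of pyridin-3-yl on this aromatic carbon gives an at least 90-fold higher number from compound 2 to compound 3 (1.95 log units; beyond the scatter) in this assay. The position therefore responds sharply to a change in the ring's hetero atoms, even with the heavy-atom count unchanged, which compound 2 alone could not show. The value for compound 3 is a limit, not a number: the limit of > 100000 nM in this assay, at which 1 of the 3 values shown sits.

This single pair gives no reason for the step. From the compounds shown here alone, how phenyl at this position, or an amine on the pyridin-3-yl ring, would read in this assay remains open.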